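The source may hold more compounds than are shown below. What is called first, only, known or untested is meant among the compounds shown, and "the series" means these compounds.

Working notes on the series. Compound 2 `Nc1nc(CC2CCCCC2)c(-c2ccccc2Br)n1CC(=O)Nc1ccccc1` carries a cyclohexyl group on the saturated chain carbon bound to an aromatic carbon of the shared core; in a functional assay on A-375 cells (Homo sapiens) for antiproliferative activity, read by MTT assay, with a stated time of 48 h (on this read-out lower numbers stand for stronger inhibition and higher numbers for weaker inhibition), compound 2 gives 40600 nM. Its closest measured neighbour is compound 1 `CCCCCc1nc(N)n(CC(=O)Nc2ccccc2)c1-c1ccccc1Br`, which has butyl at that place; in this assay compound 1 gives 26400 nM. Of the two numbers seen so far, compound 2 sits at the higher one, but the step of a 1.5-fold higher number from compound 1 to compound 2 (0.19 log units; within the scatter) lies within the scatter, so the two compounds are not separated by the data.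

Compound 3 `Cc1ccc(Cc2nc(N)n(CC(=O)Nc3ccccc3)c2-c2ccccc2Br)cc1` takes the next step at the same place: 4-methylphenyl in place of cyclohexyl on a saturated chain carbon bound to an aromatic carbon. Within the data shown here, the only measured step bearing on this position is the one from compound 1 to compound 2, which exchanged one saturated group for another and gave a 1.5-fold higher number from compound 1 to compound 2 (0.19 log units; within the scatter); no measured step exchanges a saturated ring for an aromatic one, so the data give no direction for this change. On that basis no step beyond the scatter is expected in this assay, and the estimated step is a 1.2-fold lower number from compound 2 to compound 3 (0.06 log units; within the scatter). Compound 3 is therefore expected to give about 35000 nM, within a range of 12000 nM to 100000 nM.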

Compound 3, half-maximal inhibitory concentration: 2500 nM
For compound 3 the middle estimate is 14-fold (1.15 log units) above the measured one; the measured number lies below the stated range.
By their numbers in this assay, from the lowest: compound 3; then compounds 1 and 2 (each within the scatter of the next).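

At this place, on a saturated chain carbon bound to an aromatic carbon, the group carried does change the result in this assay: 4-methylphenyl in place of cyclohexyl gives a 16-fold lower number from compound 2 to compound 3 (1.21 log units; beyond the scatter) and 4-methylphenyl in place of butyl gives an 11-fold lower number from compound 1 to compound 3 (1.02 log units; beyond the scatter) as well. The two saturated groups are not separated from each other by the data, yet each is separated from 4-methylphenyl by a step beyond the scatter, which makes compound 3 the most potent of the three compounds in this assay and shows that this position can respond strongly to the change from a non-aromatic to an aromatic ring. Nothing available here bears on the reason for this large step.

The change exchanges the ring and brings in the methyl group together, so the compounds shown do not tell how much of the step belongs to the aromatic ring itself and how much to the methyl group. A plain phenyl group would separate the two, while a 4-methoxyphenyl or 4-chlorophenyl group would show whether the methyl group can be exchanged at this place.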